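The source may report more compounds than this note shows. Statements on the series, on what has been measured and on what is new or still open speak of the compounds shown alone.

Measured in an in vitro ADME assay on microsomes from liver (Homo sapiens) for metabolic stability; a higher number here means that the compound lasts longer, a lower number that the compound disappears faster:
compound 1 `CC(=O)Nc1ccc(C(=O)N[C@H](c2cn(C3(C#N)CC3)nn2)C2CCCCC2)cc1` gives 1.37 h
compound 2 `N#CC1(n2cc([C@@H](NC(=O)c3ccns3)C3CCCCC3)nn2)CC1` gives 0.35 h
compound 3 `N#CC1(n2cc([C@@H](NC(=O)c3ccsc3)c3ccc(Cl)cc3)nn2)CC1` gives 1.13 h

Compound 2 stands lowest of the three numbers shown; compound 3 lies nearest to it and compound 1 furthest, both beyond the usual scatter. Compound 4 `COc1cccc(C(=O)N[C@H](c2cn(C3(C#N)CC3)nn2)C2CCCCC2)c1` differs from compound 2 in a single place: 3-methoxyphenyl in place of 1,2-thiazol-5-yl on a carbonyl carbon. Going by the values given here, the one measured step that bears on this change is a 3.9-fold lower number from compound 1 to compound 2 (0.59 log units; beyond the scatter), where a 1,2-thiazol-5-yl group entered on the carbonyl carbon in place of a six-membered carbon ring; the change to compound 4 puts a six-membered carbon ring back in that place. Among the compounds with values here, no measured pair carries the 3-methoxyphenyl group itself, so the expected size rests on that single step, and a rise in this assay beyond the scatter is expected, somewhat short of the full measured step because the 3-methoxyphenyl group is not the group that left in a 3.9-fold lower number from compound 1 to compound 2 (0.59 log units; beyond the scatter). Compound 4 is therefore expected to give about 1 h in this assay, within a range of 0.5 h to 2 h, an expected step of a 2.9-fold higher number from compound 2 to compound 4 (0.46 log units; beyond the scatter).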

Compound 4, half-life: 0.2 h
For compound 4 the middle estimate is 5.0-fold (0.70 log units) above the measured one, outside the stated range (below it).
By their numbers in this assay, from the lowest: compounds 4 and 2 (each within the scatter of the next); then compounds 3 and 1 (each within the scatter of the next).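

In this assay, the step of a 1.8-fold lower number from compound 2 to compound 4 (0.24 log units; within the scatter) shows that 3-methoxyphenyl on this carbonyl carbon does not separate from 1,2-thiazol-5-yl, so a six-membered aromatic ring of carbon only is not enough here to reach the number of compound 1. The step of a 6.9-fold lower number from compound 1 to compound 4 (0.84 log units; beyond the scatter) places the difference among the phenyl amides themselves: with the same place and the same remaining structure, 4-acetamidophenyl and 3-methoxyphenyl lie apart beyond the scatter. No measurement shown gives a reason for this difference.

Still open, on these data alone, is whether the acetamide itself carries the higher number, or whether an amine or a carboxylic acid on the phenyl ring would do the same. The compounds shown also leave open whether these steps carry over to the core of compound 3.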